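This account rests on a few compounds, and the source may have more. Where it says the series, first, only, none or still open, it means among the compounds named here.

In a functional assay on HCT-116 cells (Homo sapiens) for antiproliferative activity, read by MTT assay, with a stated time of 48 h (on this read-out higher numbers stand for weaker inhibition and lower numbers for stronger inhibition), compound 1 (`CCCCCC(CCO)n1cnc2c(Cl)ncnc21`) gives > 50000 nM, which is a limit of the assay. Compound 3 (`CCCCCC(CCO)n1cnc2cncnc21`) gives > 50000 nM, also a limit. Compound 2 (`CCCCCC(CCO)n1cnc2c(OC)ncnc21`) gives > 50000 nM, again only a limit. The evidence so far is the limit of > 50000 nM in this assay, at which 3 of the 3 values shown sit. Compound 4 (`CCCCCCCCCCCC(CCO)n1cnc2c(OC)ncnc21`) differs from compound 2 by hexyl in place of hydrogen on a saturated chain carbon, six bonds along the chain from an aromatic nitrogen. The measured steps are a step that the two limits leave unreadable from compound 1 to compound 2, a step that the two limits leave unreadable from compound 1 to compound 3 and a step that the two limits leave unreadable from compound 2 to compound 3. All three change a group on an aromatic carbon, not the chain, and none has a readable size. Only a tentative, modest gain in this assay is therefore expected, and the expected change is an at least 1.6-fold lower number from compound 2 to compound 4 (0.22 log units; that floor lies within the scatter). The estimate for compound 4 is 30000 nM, with an expected range of 8000 nM to 80000 nM.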

Compound 4, half-maximal inhibitory concentration: 8230 nM
For compound 4 the middle estimate is 3.6-fold (0.56 log units) above the measured one, within the range that was stated.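

In this assay, the chain position gives the only readable step among the compounds shown: an at least 6.0-fold lower number from compound 2 to compound 4 (0.78 log units; beyond the scatter). The earlier steps, all changes of the group on an aromatic carbon, cannot be read, so this shows that lengthening the chain by hexyl at this place can bring a compound of this series off the limit shared by the others: the limit of > 50000 nM in this assay, at which 3 of the 4 values shown sit.

The compounds shown leave open whether a longer chain would lower the number further, and whether the same hexyl gain holds with chloro in place of methoxy. They also leave open whether an amine could replace the hydroxyl on the short arm of the chain.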